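Extending the Saturated Chain: From Compound 2 to Compound 4

The compounds below may be only part of what the source reports. "The series", "measured", "known", "first", "only" and "open" are said of these compounds alone.

Of the compounds shown here, three that share one core have been measured in an assay on microsomes from intestine for inhibition of acyl-CoA:cholesterol acyltransferase (Oryctolagus cuniculus); on this read-out higher numbers stand for weaker inhibition and lower numbers for stronger inhibition. Compound 1 `CCCCCCCC(C)(C)C(=O)Nc1c(OC)cc(OC)cc1OC` gives 180 nM. Compound 2 `CCCCCCCCCCCCC(C)(C)C(=O)Nc1c(OC)cc(OC)cc1OC` gives 63 nM. Compound 3 `CCCCCCCCCCCCCCC(=O)Nc1c(OC)cc(OC)cc1OC` gives 65 nM. Compound 2 and compound 3 thus give numbers within the scatter of each other, and both stand beyond the scatter from compound 1. Among the measured compounds shown here, the only step between measured compounds that differ at a single site is a 2.9-fold lower number from compound 1 to compound 2 (0.46 log units; beyond the scatter). Compound 4 `CCCCCCCCCCCCCCCCC(C)(C)C(=O)Nc1c(OC)cc(OC)cc1OC` is not yet measured; from compound 2 it differs by butyl in place of hydrogen on a saturated chain carbon, ten or more bonds along the chain from a carbonyl carbon. This is the same kind of change that separates compound 1 from compound 2, carried further out along the chain. That earlier step was modest, and a second lengthening need not repeat it in full. Compound 4 is therefore expected to give 45 nM in this assay, within a range from 20 nM to 120 nM. The step expected is a 1.4-fold lower number from compound 2 to compound 4 (0.15 log units; within the scatter), a small improvement or none beyond the scatter.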

Compound 4, half-maximal inhibitory concentration: 87 nM
Estimate against measurement, compound 4: 1.9-fold (0.29 log units) below, within the range that was stated.
By their numbers in this assay, from the lowest: compounds 2, 3 and 4 (each within the scatter of the next); then compound 1.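

In this assay, butyl in place of hydrogen on a saturated chain carbon, ten or more bonds along the chain from a carbonyl carbon, gives a 1.4-fold higher number from compound 2 to compound 4 (0.14 log units; within the scatter), so this further lengthening brings no change that can be told from the scatter, unlike the earlier step of a 2.9-fold lower number from compound 1 to compound 2 (0.46 log units; beyond the scatter). The full addition of nonyl still leaves a real difference, a 2.1-fold lower number from compound 1 to compound 4 (0.32 log units; beyond the scatter). Across these three compounds, then, the gain from a longer chain appears with the first extension and does not grow with the second.

Nothing measured here bears on why chain length acts this way. Also open, as far as these compounds go, is how ethyl, an amine or a carboxylic acid would compare with butyl at this position.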